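Compound 3 and the step from compound 2

The compounds below may be only part of what the source reports. "The series", "measured", "known", "first", "only" and "open" are said of these compounds alone.

Measured in a physicochemical assay for solubility; on this read-out lower numbers stand for lower solubility and higher numbers for higher solubility:

Compound 1 `CNC(=O)c1cc(C(=O)NC2CC2)cn(Cc2cccc(OC)c2)c1=O` reads 79 ug/mL as a number

Compound 2 `CNC(=O)c1cc(C(=O)NC2CC2)cn(Cc2ccccc2F)c1=O` reads >= 145 ug/mL as a limit

Compound 2 stands at the limit of >= 145 ug/mL in this assay, at which 1 of the 2 values shown sits, and so has a limit rather than a number. Compound 3 `CNC(=O)c1cc(C(=O)NC2CC2)cn(Cc2cccc(C#N)c2)c1=O` has not been measured yet. It carries 3-cyanophenyl in place of 2-fluorophenyl on a saturated chain carbon bound to an aromatic nitrogen and otherwise matches compound 2. Within the data shown here, one measured step bears on this place, namely an at least 1.8-fold higher number from compound 1 to compound 2 (0.26 log units; that floor lies within the scatter) and it gives only a floor within the scatter. On that single step, no change beyond the scatter is expected in this assay and the direction stays uncertain. The expected step is an at least 1.3-fold lower number from compound 2 to compound 3 (0.11 log units; that floor lies within the scatter) and it remains an estimate. Compound 3 is estimated at 110 ug/mL with an expected range from 50 ug/mL to 170 ug/mL in this read-out.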

Compound 3, solubility: >= 148 ug/mL
Compound 3: no number, only a limit; the forecaster's own chance of this, stated with the estimate: 25%; at least 1.3-fold (0.12 log units) between middle value and limit.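

In this assay compound 3 gives a limit and not a number: the limit of >= 148 ug/mL in this assay, at which 1 of the 3 values shown sits. Set against compound 1, which has a number, the change of cyano in place of methoxy on an aromatic carbon gives an at least 1.8-fold higher number from compound 1 to compound 3 (0.27 log units; that floor lies within the scatter), so it is only a floor and shows no change that can be claimed. Compound 2 also gives a limit, which means that 2-fluorophenyl and 3-cyanophenyl, the groups at this place on a saturated chain carbon bound to an aromatic nitrogen, cannot be put in order, and the step between these two compounds cannot be read.

From the compounds shown here alone, the true values of compound 2 and compound 3 remain open. So does how this assay would read with an amine or a carboxylic acid in place of the cyano on the aromatic carbon.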